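Swapping the aryl group on a sulfonyl in a receptor binding series

The compounds below may be only part of what the source reports. "The series", "measured", "known", "first", "only" and "open" are said of these compounds alone.

Of the compounds shown here, three that share one core have been tested in an assay on isolated protein for displacement of a labelled ligand from metabotropic glutamate receptor 5 (Homo sapiens), with a stated time of 60 min, tested at 1 uM; a lower number here means less inhibition, a higher number more inhibition at the concentration tested (going by the name of the read-out). Compound 1, with structure `Cc1ccc(S(=O)(=O)c2cnc3cc(Cl)ccc3c2N2CCC(C)CC2)cc1F`, gives 85%. Compound 2, with structure `COc1ccc2ncc(S(=O)(=O)c3ccc(Cl)c(Cl)c3)c(N3CCC(C)CC3)c2c1`, gives 87%, and compound 3, with structure `CC1CCN(c2c(S(=O)(=O)c3ccc(Cl)cc3)cnc3cc(F)ccc23)CC1`, gives 90%. The three numbers sit close together: the gap from compound 1 to compound 2 and the gap from compound 1 to compound 3 both fall within the usual scatter of this kind of measurement, so no ranking among them can be read from these values. What the three do show is that varying the aryl group on the sulfonyl sulfur, while keeping the rest of the molecule, has so far left the read-out in the same region.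

Compound 4, with structure `CC1CCN(c2c(S(=O)(=O)c3cccc(C#N)c3)cnc3cc(Cl)ccc23)CC1`, has not yet been measured in this assay . Compared with compound 1, its structure differs in one place: 3-cyanophenyl in place of 3-fluoro-4-methylphenyl on a sulfonyl sulfur. Because the numbers for compound 1, compound 2 and compound 3 in this assay lie within the scatter of one another despite differing aryl groups at this same position, the expected step from a number 5 percentage points lower from compound 1 to compound 4 (within the scatter) is small, leaning slightly downward but not clearly beyond the scatter. Compound 4 is therefore expected to give about 80% in this assay , with a plausible range from 60% to 92%.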

Compound 4, a percentage reported as inhibition, at one concentration (the size of the read-out at that concentration, not a potency): 94%
Compound 4: the middle estimate sits 14 percentage points below what was measured; measured number outside the range, above it.
By their numbers in this assay, from the lowest: compounds 1, 2, 3 and 4 (each within the scatter of the next).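

In this assay, within the data shown here, 3-cyanophenyl in place of 3-fluoro-4-methylphenyl on the sulfonyl sulfur gives a number 9 percentage points higher from compound 1 to compound 4 (within the scatter), and this is the first pair that differs in only one place. The earlier compounds shown here differed from one another in more than one place, whereas here the rest of the molecule stays fixed, and a ring carrying a nitrile, with a hydrogen-bond acceptor that the departing group lacks, replaces a ring carrying a methyl and a fluorine without taking the read-out beyond the scatter. Nothing available here offers an explanation for this result.

From the compounds shown here alone, all four compounds carry a substituted phenyl ring on the sulfonyl sulfur, so it remains open whether a carboxylic acid or an amine on that ring, or a saturated cyclohexyl ring in place of the phenyl, would keep the number in the same region. Going by these compounds, it also remains open whether compound 1 and compound 4 would separate on a true potency scale, since a percentage at a single concentration is not a potency.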